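Thiazole replaces the hydroxyalkyl pyrazole on the ring nitrogen

The source may report more compounds than this note shows. Statements on the series, on what has been measured and on what is new or still open speak of the compounds shown alone.

Compound 3 `Cc1ccc(CNC(=O)c2cccc(C(C)Oc3cccnc3Nc3cnn(CC(C)(C)O)c3)c2)cc1` holds the lowest of the two numbers recorded so far in a functional assay on HCC78 cells (Homo sapiens) for antiproliferative activity, read by MTT assay, with a stated time of 48 h; on this read-out lower numbers stand for stronger inhibition and higher numbers for weaker inhibition: compound 3 gives 20500 nM. Compound 1 `CC(Oc1cccnc1Nc1cnn(C)c1)c1cccc(C(=O)NCc2ccccc2S(=O)(=O)C(C)C)c1` gives 63100 nM in this assay, a higher number than compound 3 by a margin beyond the scatter. Compound 2 `Cc1ccc(CNC(=O)c2cccc(C(C)Oc3cccnc3Nc3ncccn3)c2)cc1` is reported only as a limit, > 100000 nM, and not as a number (the limit of > 100000 nM in this assay, at which 1 of the 3 values shown sits). Within the data shown here, the one step measured so far is an at least 4.8-fold lower number from compound 2 to compound 3 (0.68 log units; beyond the scatter), the exchange of pyrimidin-2-yl for 1-(2-hydroxy-2-methylpropyl)-1H-pyrazol-4-yl on the nitrogen on the aromatic ring.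

Compound 4 `Cc1ccc(CNC(=O)c2cccc(C(C)Oc3cccnc3Nc3nccs3)c2)cc1` differs from compound 3 in that same place: 1,3-thiazol-2-yl in place of 1-(2-hydroxy-2-methylpropyl)-1H-pyrazol-4-yl on a nitrogen on an aromatic ring. Among the measured compounds shown here, the only step that bears on this change is an at least 4.8-fold lower number from compound 2 to compound 3 (0.68 log units; beyond the scatter), in which the hydroxyalkyl pyrazole brought the number down from a limit. Compound 4 now gives that pyrazole up for another five-membered aromatic ring with two hetero atoms, carrying no hydrogen-bond donor, so the expectation is that the number moves back upward, by a modest step or more, with a real chance that only a limit is returned. Compound 4 is therefore estimated at 70000 nM, expected between 25000 nM and 100000 nM. The expected step is a 3.4-fold higher number from compound 3 to compound 4 (0.53 log units; beyond the scatter).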

Compound 4, half-maximal inhibitory concentration: 27100 nM
Beside the measured number, compound 4's estimate is 2.6-fold (0.41 log units) above it; the measured number falls inside the stated range.
By their numbers in this assay, from the lowest: compounds 3 and 4 (each within the scatter of the next); then compound 1. At a limit, above all of these: compound 2.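

In this assay, the exchange on the nitrogen on an aromatic ring gives a 1.3-fold higher number from compound 3 to compound 4 (0.12 log units; within the scatter), so the two groups cannot be told apart at this position, even though 1,3-thiazol-2-yl carries no hydrogen-bond donor and lacks the 2-hydroxy-2-methylpropyl chain. Among these compounds, then, neither that chain nor its hydrogen-bond donor is needed for a number of this size, and the step away from pyrimidin-2-yl no longer rests on the hydroxyalkyl pyrazole alone, since 1,3-thiazol-2-yl in that place gives an at least 3.6-fold lower number from compound 2 to compound 4 (0.56 log units; beyond the scatter). That step has a fixed size only on one side, as compound 2 is reported as a limit and not as a number: the limit of > 100000 nM in this assay, at which 1 of the 4 values shown sits.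

Both groups that stand at this level are five-membered aromatic rings with 2 hetero atoms, so the compounds shown cannot separate the effect of that ring type from that of the particular group, and a phenyl ring or an unsubstituted pyrazol-4-yl on this nitrogen would test it. From the compounds shown here alone, it also remains open whether a thiazole bearing a carboxylic acid or an amine would keep, or move away from, the number of compound 4.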